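Halogen swap on the aroyl group, measured once and expected again

The compounds below may be only part of what the source reports. "The series", "measured", "known", "first", "only" and "open" are said of these compounds alone.

Three members of one series have been tested in a functional assay on HeLa cells (Homo sapiens) for inhibition, read by MTT assay, with a stated time of 72 h; a higher number here means a weaker inhibitor, a lower number a stronger inhibitor. Compound 1 `CN(C(=O)NC(=O)c1ccc(F)c(F)c1)c1nc(C(F)(F)F)c(C(=O)N/N=C/c2ccccc2C(F)(F)F)s1` gives 9.24 ug/mL. Compound 2 `CN(C(=O)NC(=O)c1ccc(F)c(F)c1)c1nc(C(F)(F)F)c(C(=O)N/N=C/c2cc(C(F)(F)F)cc(C(F)(F)F)c2)s1` gives 4.45 ug/mL; compounds 1 and 2 differ in more than one place, and the difference between the two cores is not broken down here, but compound 1 gives the higher number of the two. Compound 3 `CN(C(=O)NC(=O)c1ccc(Cl)cc1Cl)c1nc(C(F)(F)F)c(C(=O)N/N=C/c2cc(C(F)(F)F)cc(C(F)(F)F)c2)s1` does not yield a number: its result is a limit of this assay, > 100 ug/mL, namely (the limit of > 100 ug/mL in this assay, at which 1 of the 3 values shown sits).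

Compound 3 differs from compound 2 by a single change, (2,4-dichlorophenyl in place of 3,4-difluorophenyl on a carbonyl carbon). That change produced an at least 22-fold higher number from compound 2 to compound 3 (1.35 log units; beyond the scatter), a large step in the direction of weaker inhibition.

Compound 4 `CN(C(=O)NC(=O)c1ccc(Cl)cc1Cl)c1nc(C(F)(F)F)c(C(=O)N/N=C/c2ccccc2C(F)(F)F)s1` is not yet measured. It stands to compound 1 exactly as compound 3 stands to compound 2: the same change, at the same place, (2,4-dichlorophenyl in place of 3,4-difluorophenyl on a carbonyl carbon).

Going by the values given here, the expectation for compound 4 rests on compound 2 and compound 3, because the one measured instance of this change gave an at least 22-fold higher number from compound 2 to compound 3 (1.35 log units; beyond the scatter). Compound 4 is therefore expected to reach only the limit of this assay rather than a number, and the expected step is a 16-fold higher number from compound 1 to compound 4 (1.21 log units; beyond the scatter). As a point estimate, compound 4 is expected at 150 ug/mL, with a plausible range from 40 ug/mL to 600 ug/mL.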

Compound 4, half-maximal inhibitory concentration: 9 ug/mL
Beside the measured number, compound 4's estimate is 17-fold (1.22 log units) above it, and the stated range ends above it.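

In this assay, placing 2,4-dichlorophenyl in place of 3,4-difluorophenyl on a carbonyl carbon gave a 1.0-fold lower number from compound 1 to compound 4 (0.01 log units; within the scatter), so on the core of compound 1 this change left the reading unmoved. The change therefore did not carry over from one core to the other, and the earlier step is no guide to this one: the same change on two cores in this assay, an at least 22-fold higher number (1.35 log units; beyond the scatter) from compound 2 to compound 3 and a 1.0-fold lower number (0.01 log units; within the scatter) from compound 1 to compound 4, at least 23-fold (1.36 log units) apart, beyond the scatter of two such steps. Going by these compounds, compound 3 gives a limit of the assay rather than a number, so the true size of the earlier step stays unknown, and two pairs cannot show which feature of the cores decides the outcome: the limit of > 100 ug/mL in this assay, at which 1 of the 4 values shown sits.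

The compounds shown leave open whether the loss seen with compound 3 belongs to the chlorine atoms or to their arrangement on the ring, since the two groups compared change both at once. They also leave open how either core would respond to a phenyl group carrying a methoxy group or a nitrile in place of the halogens, and so whether compound 1 and compound 4 or compound 2 and compound 3 show the more typical behaviour in this series.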